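A methylsulfanyl for a trifluoromethoxy on the aryl ring

The source may hold more compounds than are shown below. What is called first, only, known or untested is meant among the compounds shown, and "the series" means these compounds.

Of the compounds shown here, two have been measured in a functional assay for antagonist activity at Alpha-1A adrenergic receptor (Oryctolagus cuniculus); on this read-out lower numbers stand for tighter binding and higher numbers for weaker binding. Compound 1 `COc1ccccc1N1CCN(CCCNc2ccc(C(=O)N(C)C)cn2)CC1` gives 25.1 nM. Compound 2 `CN(C)C(=O)c1cccnc1NCCCN1CCN(c2ccccc2OC(F)(F)F)CC1` gives 3.16 nM, the lowest of the two numbers; compound 1 sits at a higher number by a gap that lies beyond the usual scatter of repeated measurements. Compound 3 `CSc1ccccc1N1CCN(CCCNc2ncccc2C(=O)N(C)C)CC1` has not yet been tested in this assay. It differs from compound 2 in one place: methylsulfanyl in place of trifluoromethoxy on an aromatic carbon, on an aromatic carbon ortho to a large group. Within the data shown here, no pair measured so far differs in exactly this way, so the size of the step cannot be read from the numbers at hand, and compound 1 differs from compound 2 in more than one place and cannot serve as a guide. The change is expected to move the number little, if at all, and to stay within the scatter, so the step from compound 2 to compound 3 is estimated as a 1.6-fold higher number from compound 2 to compound 3 (0.20 log units; within the scatter). Compound 3 is therefore expected to give about 5 nM in this assay, with a plausible range from 1.5 nM to 16 nM.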

Compound 3, dissociation constant: 0.631 nM
Estimate against measurement, compound 3: 7.9-fold (0.90 log units) above; measured number below the stated range.
By their numbers in this assay, from the lowest: compound 3; then compound 2; then compound 1.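

In this assay, putting methylsulfanyl in place of trifluoromethoxy on an aromatic carbon ortho to a large group gives a 5.0-fold lower number from compound 2 to compound 3 (0.70 log units; beyond the scatter), so this position responds clearly to the choice of group. Compound 3 binds more tightly even though the entering group has fewer heavy atoms, which shows that a larger group is not needed here for tight binding, at least in this one pair; the two groups have the same count of hydrogen-bond donors and of acceptors, so those counts do not tell them apart. Nothing measured here explains why the number falls with this change.

This single pair cannot show how this assay would respond to other groups at this position, such as a chlorine atom, a methyl group or an ethylsulfanyl group, so it remains unclear whether the sulfur atom or some other feature of methylsulfanyl matters. From the compounds shown here alone, it also remains open whether the step would carry over to the core of compound 1, which differs from compound 2 in more than one place.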